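Ether side-chain change from compound 3

The source may hold more compounds than are shown below. What is called first, only, known or untested is meant among the compounds shown, and "the series" means these compounds.

In a functional assay on the whole organism with Mus musculus as the target (a higher number here means that more compound is needed for the effect, a lower number that less compound is needed), compound 1 `C[C@@H](NCc1ccc(OCc2ccccc2)cc1)C(N)=O` gives 23.8 mg/kg, compound 2 `CNC(=O)[C@H](NCc1ccc(OCc2ccccc2)cc1)C(C)C` gives 112 mg/kg and compound 3 `C[C@@H](NCc1ccc(OCCc2ccccc2)cc1)C(N)=O` gives 24.9 mg/kg. Compound 3 sits level with compound 1 at the low end of these numbers, and the number of compound 2 is higher than both. Next is compound 4 `C[C@@H](NCc1ccc(OCc2ccccc2Cl)cc1)C(N)=O`, with the change 2-chlorophenyl in place of benzyl on a saturated chain carbon bound to an oxygen on an aromatic ring. The closest evidence is the step at this same place, a 1.0-fold higher number from compound 1 to compound 3 (0.02 log units; within the scatter), which stayed within the scatter. The larger 4.7-fold higher number from compound 1 to compound 2 (0.67 log units; beyond the scatter) lies on an amine nitrogen and bears little on this change. Within the data shown here, no measured compound carries chlorine. No step beyond the scatter is therefore expected in this assay, and the expected step is a 1.1-fold lower number from compound 3 to compound 4 (0.03 log units; within the scatter). For compound 4 the estimate is 23 mg/kg, with an expected range of 11 mg/kg to 50 mg/kg.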

Compound 4, dose for half-maximal effect: 17.4 mg/kg
The estimate for compound 4 lay 1.3-fold (0.12 log units) above the measured number; measured number inside the range.
By their numbers in this assay, from the lowest: compounds 4, 1 and 3 (each within the scatter of the next); then compound 2.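

In this assay, chlorine now appears in the series, and the first substituent on the aromatic ring of this side chain leaves the number level with both close relatives (a 1.4-fold lower number from compound 3 to compound 4 (0.16 log units; within the scatter); a 1.4-fold lower number from compound 1 to compound 4 (0.14 log units; within the scatter)). Both steps lie within the scatter, so phenyl, benzyl and 2-chlorophenyl on this saturated chain carbon bound to an oxygen on an aromatic ring cannot be told apart. Nothing available explains this level reading.

Going by these compounds, whether an amine, a carboxylic acid or a longer chain at this place would give a step beyond the scatter remains open. On these data alone, it is also open whether chloro would behave the same way alongside the 2-methyl-1-(methylcarbamoyl)propyl group of compound 2.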